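A Butoxy Group in Place of a Fluorophenyl Carbonyl

The compounds below may be only part of what the source reports. "The series", "measured", "known", "first", "only" and "open" are said of these compounds alone.

Measured compounds:
compound 1, `Cc1ccc(Nc2nc(C(F)(F)F)ccc2CNC(=O)C(C)c2ccc(NS(C)(=O)=O)c(F)c2)cc1C`, in a functional assay on CHO-K1 cells for antagonist activity at transient receptor potential cation channel subfamily V member 1 (Homo sapiens), read by FLIPR (a lower number here means a stronger inhibitor, a higher number a weaker inhibitor), compound 1 gives 1160 nM
compound 2, `CC(C(=O)NCc1ccc(C(F)(F)F)nc1N1CCC(C(=O)c2ccc(F)cc2)CC1)c1ccc(NS(C)(=O)=O)c(F)c1`, in this assay compound 2 gives 990 nM

Compound 2 shows the lowest of the two numbers, but compound 1 sits within the usual scatter of it, so the two measured values cannot be told apart on the evidence at hand. Among the compounds with values here, no pair of measured compounds differs in one place, so there is no measured step to guide the next change.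

Compound 3, `CCCCOC1CCN(c2nc(C(F)(F)F)ccc2CNC(=O)C(C)c2ccc(NS(C)(=O)=O)c(F)c2)CC1`, keeps the shared core of compound 2 and alters only the group on the saturated ring: butoxy in place of (4-fluorophenyl)carbonyl on a saturated ring carbon. Nothing measured here speaks to what such an exchange does, since the two measured compounds differ from each other in more than one place.

Within the data shown here, with no comparable step to draw on, compound 3 is expected to stay close to compound 2, a change of about a 1.0-fold higher number from compound 2 to compound 3 (0.00 log units; within the scatter), not beyond the scatter in either direction. The value for compound 3 is estimated at 1000 nM, within a range of 300 nM to 3500 nM.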

Compound 3, half-maximal inhibitory concentration: 28.2 nM
Beside the measured number, compound 3's estimate is 35-fold (1.55 log units) above it; the whole stated range lies above it.
By their numbers in this assay, from the lowest: compound 3; then compounds 2 and 1 (each within the scatter of the next).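

In this assay, within the data shown here, butoxy in place of (4-fluorophenyl)carbonyl on a saturated ring carbon gives a 35-fold lower number from compound 2 to compound 3 (1.55 log units; beyond the scatter), the first sign that the group at this position can change the number by far more than the scatter. The group of 11 heavy atoms carrying this butoxy, with its six-membered non-aromatic ring, in place of the group of 9 heavy atoms with its six-membered aromatic ring of carbon only, on an aromatic carbon, gives a 41-fold lower number from compound 1 to compound 3 (1.61 log units; beyond the scatter), so compound 3 now stands well apart from two compounds that could not be told apart from each other. Nothing in the data shown accounts for the size of these steps.

The exchange removes an aromatic ring and a carbonyl and brings in an oxygen-linked open chain all at once, so the compounds shown leave open which of these parts carries the difference. A propoxy or pentyloxy chain, a butyl chain without the oxygen, or a benzyloxy group on the same saturated ring carbon would separate these parts and show how far the chain's length and its oxygen matter.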